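The source may report more compounds than this note shows. Statements on the series, on what has been measured and on what is new or still open speak of the compounds shown alone.

Measured compounds in an ADME assay on HeLa cells (Homo sapiens) for inhibition, read by MTT assay; a higher number here means a weaker inhibitor of growth, a lower number a stronger inhibitor of growth:
compound 1, `Cc1ccc(O)c(C(=O)/C=C/c2cn(-c3ccc(F)cc3)nc2-c2sc(C)nc2C)c1` — 29.9 ug/mL
compound 2, `Cc1nc(C)c(-c2nn(-c3ccc(F)cc3)cc2/C=C/C(=O)c2cc(Cl)c(C)cc2O)s1` — 34.9 ug/mL

Among the measured compounds shown here, compound 1 holds the lowest of the two numbers measured so far in this assay; the nearest is compound 2, with a step of a 1.2-fold higher number from compound 1 to compound 2 (0.07 log units; within the scatter), so the two compounds are not separated by this assay.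

Compound 3, `Cc1nc(C)c(-c2nn(-c3ccc(F)cc3)cc2/C=C/C(=O)c2c(O)cc(C)c(Cl)c2C)s1`, is not yet measured. It differs from compound 1 as follows: 3-chloro-6-hydroxy-2,4-dimethylphenyl in place of 2-hydroxy-5-methylphenyl on a carbonyl carbon. For the measured compounds named here, the one measured step that bears on this change is the one from compound 1 to compound 2, a 1.2-fold higher number from compound 1 to compound 2 (0.07 log units; within the scatter), where the same aryl group on the carbonyl carbon was exchanged for a chloro- and methyl-bearing hydroxyphenyl and the number stayed within the scatter. Going by the values given here, compound 3 carries a further methyl on that ring in addition to the chlorine, but no measured pair speaks to that addition on its own. The expected step is therefore a 1.1-fold higher number from compound 1 to compound 3 (0.04 log units; within the scatter), that is, none beyond the scatter, with the range widened somewhat for the untested extra methyl. In this assay compound 3 is expected to give 33 ug/mL, within a range of 16 ug/mL to 70 ug/mL.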

Compound 3, concentration for 50% growth inhibition: 59.3 ug/mL
For compound 3 the middle estimate is 1.8-fold (0.25 log units) below the measured one, within the range that was stated.
By their numbers in this assay, from the lowest: compounds 1, 2 and 3 (each within the scatter of the next).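

In this assay, the step of a 2.0-fold higher number from compound 1 to compound 3 (0.30 log units; within the scatter) shows that 3-chloro-6-hydroxy-2,4-dimethylphenyl can stand in place of 2-hydroxy-5-methylphenyl on the carbonyl carbon without leaving the scatter, although this step lies at its edge. Among the compounds shown here, the step of a 1.7-fold higher number from compound 2 to compound 3 (0.23 log units; within the scatter) gives the first reading of methyl in place of hydrogen on an aromatic carbon of this aryl group, and it does not separate the two compounds either, so no step among compound 1, compound 2 and compound 3 lies beyond the scatter. No measurement at hand offers an explanation for these numbers.

The compounds shown leave open whether an amine or a carboxylic acid in place of the chlorine would give a step beyond the scatter. For the compounds shown here, the chlorine also remains unread on its own, since the only compounds carrying it differ from compound 1 in the placement or number of methyl groups as well.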